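This account rests on a few compounds, and the source may have more. Where it says the series, first, only, none or still open, it means among the compounds named here.

Of the compounds shown here, three have been measured in an assay on isolated protein for inhibition of leukotriene A-4 hydrolase (Homo sapiens); a lower number here means a stronger inhibitor, a higher number a weaker inhibitor. Compound 1 `N=c1scc(-c2ccccc2)n1CC(=O)N1CCOCC1` gives 8650 nM. Compound 2 `Cc1ccc(-c2csc(=N)n2CC(=O)N2CCN(C)CC2)cc1` gives 369 nM. Compound 3 `CN1CCN(C(=O)Cn2c(-c3ccccc3)csc2=N)CC1` gives 629 nM.

Compound 3 and compound 1 share a core and differ only at the amide end, where the change is morpholin-4-yl in place of 4-methylpiperazin-1-yl on a carbonyl carbon. That single change produced a 14-fold higher number from compound 3 to compound 1 (1.14 log units; beyond the scatter), the one clear effect seen among these three compounds. Compound 3 and compound 2 differ on the aromatic ring, by methyl in place of hydrogen on an aromatic carbon; the step of a 1.7-fold higher number from compound 2 to compound 3 (0.23 log units; within the scatter) is within the usual scatter, so the two numbers cannot be told apart.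

Compound 4 `Cc1ccc(-c2csc(=N)n2CC(=O)N2CCOCC2)cc1` is not yet measured. It is built from compound 2 by the change (morpholin-4-yl in place of 4-methylpiperazin-1-yl on a carbonyl carbon), the same change that turned compound 3 into compound 1, made at the same kind of position. The expectation for compound 4 therefore rests on that earlier step: an expected step of a 14-fold higher number from compound 2 to compound 4 (1.13 log units; beyond the scatter) in this assay, taken from a 14-fold higher number from compound 3 to compound 1 (1.14 log units; beyond the scatter) and applied to compound 2. Compound 4 is thus estimated at 5000 nM, expected to fall between 2000 nM and 13000 nM.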

Compound 4, inhibition constant: 3560 nM
The estimate for compound 4 lay 1.4-fold (0.15 log units) above the measured number; measured number inside the range.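

In this assay, putting morpholin-4-yl in place of 4-methylpiperazin-1-yl on the carbonyl carbon again gave a weaker inhibitor, with a 9.6-fold higher number from compound 2 to compound 4 (0.98 log units; beyond the scatter), and the size of this step matches the earlier one on the other core: the same change on two cores in this assay, a 14-fold higher number (1.14 log units; beyond the scatter) from compound 3 to compound 1 and a 9.6-fold higher number (0.98 log units; beyond the scatter) from compound 2 to compound 4, 1.4-fold (0.15 log units) apart, within the scatter of two such steps. Putting methyl in place of hydrogen on the aromatic carbon gave a 2.4-fold lower number from compound 1 to compound 4 (0.39 log units; beyond the scatter), and this step also agrees with its counterpart, although that counterpart lies within the scatter: the same change on two cores in this assay, a 1.7-fold higher number (0.23 log units; within the scatter) from compound 2 to compound 3 and a 2.4-fold higher number (0.39 log units; beyond the scatter) from compound 4 to compound 1, 1.4-fold (0.15 log units) apart, within the scatter of two such steps. Both changes therefore carried over between these two cores with much the same size, but this is a single comparison, and it shows neither why morpholin-4-yl gives the higher numbers nor whether the same would hold on a different core.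

As far as these compounds go, whether a piperidin-1-yl or a dimethylamino group on the carbonyl carbon would give a number closer to compound 2 or to compound 4 remains open. From the compounds shown here alone, the effect of a chlorine atom or a methoxy group in place of the methyl also remains open.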